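Hydroxymethyl to methoxymethyl: expected lipophilicity of compound 3

The compounds below may be only part of what the source reports. "The series", "measured", "known", "first", "only" and "open" are said of these compounds alone.

Among the compounds with values here, in a physicochemical assay for lipophilicity, read by HPLC, at pH 7.5 (on this read-out lower numbers stand for lower lipophilicity and higher numbers for higher lipophilicity), compound 1 `CC[C@@H](Nc1c(C#N)c(-c2ccc(-c3ccc(F)cc3)cc2)nc2cnccc12)C(N)=O` gives 2.7 and compound 2 `CC[C@@H](Nc1c(C#N)c(-c2ccc(-c3cccc(CO)c3)cc2)nc2cnccc12)C(N)=O` gives 2, so compound 2 holds the lower of the two numbers so far. Compound 3 `CC[C@@H](Nc1c(C#N)c(-c2ccc(-c3ccccc3COC)cc2)nc2cnccc12)C(N)=O` carries 2-(methoxymethyl)phenyl in place of 3-(hydroxymethyl)phenyl on an aromatic carbon, para to a large group: 2-(methoxymethyl)phenyl in place of 3-(hydroxymethyl)phenyl on an aromatic carbon.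

Within the data shown here, only one measured step bears on this change: a number 0.70 log units lower from compound 1 to compound 2 (beyond the scatter), a modest step beyond the scatter, which brought in the 3-(hydroxymethyl)phenyl that now leaves. Among the measured compounds shown here, no measured compound separates the loss of the hydrogen-bond donor from the shift in the group's position, so the reading is uncertain. A partial return towards the number of compound 1 seems likely.

The expected change is upward and nearly as large: a number 0.60 log units higher from compound 2 to compound 3 (beyond the scatter). For compound 3 the estimate is 2.6, with an expected range of 2.2 to 3.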

Compound 3, distribution coefficient: 2.6
Estimate against measurement, compound 3: no gap at the digits printed; the range from low to high includes it.
By their numbers in this assay, from the lowest: compound 2; then compounds 3 and 1 (each within the scatter of the next).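

Replacing 3-(hydroxymethyl)phenyl with 2-(methoxymethyl)phenyl on this aromatic carbon gives a number 0.60 log units higher from compound 2 to compound 3 (beyond the scatter) in this assay and thus shows that this position can also move the number upward. Against 4-fluorophenyl the reading is a number 0.10 log units lower from compound 1 to compound 3 (within the scatter) and places 2-(methoxymethyl)phenyl level with it, so the drop seen with 3-(hydroxymethyl)phenyl does not carry over to this ether. Nothing available explains why the number moved with this change.

Going by these compounds, the hydrogen-bond donor count and the group's place on the ring change together here, so the share of each in the step stays open. On these data alone, whether an aminomethyl group or a carboxylic acid on the same phenyl ring would lower the number further in this assay also remains open.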